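The compounds below may be only part of what the source reports. "The series", "measured", "known", "first", "only" and "open" are said of these compounds alone.

In a physicochemical assay for solubility (on this read-out higher numbers stand for higher solubility and lower numbers for lower solubility), three compounds sharing one core have been measured. Compound 1 `CC(C)(C)OC(=O)N1CCC[C@H]1C(=O)N1CCC(NS(=O)(=O)c2cc(S(=O)(=O)c3ccccc3)ccc2C(F)(F)F)CC1` reads 25000 nM and compound 2 `CC(=O)N1CCC[C@H]1C(=O)N1CCC(NS(=O)(=O)c2cc(S(=O)(=O)c3ccccc3)ccc2C(F)(F)F)CC1` reads 12500 nM in this test, while compound 3 `CC(C)(C)CC(=O)N1CCC[C@H]1C(=O)N1CCC(NS(=O)(=O)c2cc(S(=O)(=O)c3ccccc3)ccc2C(F)(F)F)CC1` reads 25000 nM on the same scale. Compound 3 thus stands level with compound 1, and its gap to compound 2 stays within the scatter.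

Compound 4 `CN(C)c1ccc(C(=O)N2CCC[C@H]2C(=O)N2CCC(NS(=O)(=O)c3cc(S(=O)(=O)c4ccccc4)ccc3C(F)(F)F)CC2)cc1` carries 4-(dimethylamino)phenyl in place of neopentyl on a carbonyl carbon. Earlier changes of the group on this carbonyl carbon gave a 2.0-fold lower number from compound 1 to compound 2 (0.30 log units; within the scatter) and no change at the digits printed from compound 1 to compound 3 (within the scatter) and also a 2.0-fold higher number from compound 2 to compound 3 (0.30 log units; within the scatter) and each of these lies within the scatter. None of these steps brought in an aromatic ring, so they guide the new change only loosely, and they do not settle its direction. A small downward move in this assay is nevertheless expected, no larger than the largest measured step. The expected step is a 2.0-fold lower number from compound 3 to compound 4 (0.30 log units; within the scatter) and it carries wide uncertainty. Compound 4 is estimated at 12500 nM with 3000 nM to 25000 nM as its expected range.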

Compound 4, solubility: 100000 nM
Estimate against measurement, compound 4: 8.0-fold (0.90 log units) below; the whole stated range lies below it.
By their numbers in this assay, from the lowest: compounds 2, 1 and 3 (each within the scatter of the next); then compound 4.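

In this assay this carbonyl carbon proves able to carry a change beyond the scatter: with 4-(dimethylamino)phenyl in place, the record shows a 4.0-fold higher number from compound 3 to compound 4 (0.60 log units; beyond the scatter) against neopentyl, a 4.0-fold higher number from compound 1 to compound 4 (0.60 log units; beyond the scatter) against tert-butoxy and an 8.0-fold higher number from compound 2 to compound 4 (0.90 log units; beyond the scatter) against methyl. The three earlier groups, all within the scatter of one another, gave no sign of this range, and compound 4 now stands beyond the scatter of every other compound shown. Nothing at hand accounts for this rise.

Going by these compounds, compound 4 brings in an aromatic ring and a dimethylamino group at once, so which of the two goes with the rise stays open, and a plain phenyl or a 4-methoxyphenyl on the same carbonyl carbon would separate them. Also open, on these data alone, is whether a saturated chain ending in a dimethylamino group would read like compound 4.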